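Inverting the Alanine Stereocentre of a Legumain Nitrile Inhibitor

The compounds below may be only part of what the source reports. "The series", "measured", "known", "first", "only" and "open" are said of these compounds alone.

Measured compounds:
compound 1, `C[C@@H](C(=O)N[C@H](C#N)CC(N)=O)N(Cc1ccc(-c2ccc(F)c(F)c2)cc1)S(C)(=O)=O`: 252 nM
compound 2, `C[C@@H](C(=O)N[C@H](C#N)CC(N)=O)N(Cc1ccc(-c2cc(F)cc(F)c2)cc1)S(C)(=O)=O`: 1360 nM
compound 3, `C[C@H](C(=O)N[C@H](C#N)CC(N)=O)N(Cc1ccc(-c2ccc(F)cc2)cc1)S(C)(=O)=O`: > 10000 nM

Going by the values given here, in an assay on isolated protein for inhibition of legumain (Homo sapiens), with stated times of 2 min and 60 min (a higher number here means a weaker inhibitor, a lower number a stronger inhibitor), compound 1 gives 252 nM and compound 2 gives 1360 nM; the only measured step, a 5.4-fold higher number from compound 1 to compound 2 (0.73 log units; beyond the scatter), concerns the fluorine pattern. For compound 3 the result is a limit of this assay, > 10000 nM, so compound 3 stands at the limit of > 10000 nM in this assay, at which 1 of the 3 values shown sits. Compound 4, `C[C@@H](C(=O)N[C@H](C#N)CC(N)=O)N(Cc1ccc(-c2ccc(F)cc2)cc1)S(C)(=O)=O`, is not yet measured; it differs from compound 3 thus: the two compounds have the same atoms and bonds and differ only in configuration as drawn: 1 of 2 stereo elements differ; a stereocentre at a saturated chain carbon is drawn R in compound 3 and S in compound 4. Among the compounds with values here, no measured step addresses this configuration change, but compounds 1 and 2 share the configuration drawn for compound 4 and both give numbers. Compound 4 is therefore expected to gain strongly, an at least 20-fold lower number from compound 3 to compound 4 (1.30 log units; beyond the scatter), estimated at 500 nM (150 nM to 2500 nM).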

Compound 4, half-maximal inhibitory concentration: 1040 nM
The estimate for compound 4 lay 2.1-fold (0.32 log units) below the measured number; the measured number falls inside the stated range.
By their numbers in this assay, from the lowest: compound 1; then compounds 4 and 2 (each within the scatter of the next). At a limit, above all of these: compound 3.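

In this assay, the configuration of the stereocentre at a saturated chain carbon matters, with an at least 9.6-fold lower number from compound 3 to compound 4 (0.98 log units; beyond the scatter), and this difference can be assigned to that centre alone because of one fact: the fact that compounds 3 and 4 differ only in the configuration as drawn. The size of that step is only a lower bound, as the value for compound 3 is a limit: the limit of > 10000 nM in this assay, at which 1 of the 4 values shown sits. With the configuration of compound 4, a 1.3-fold lower number from compound 2 to compound 4 (0.12 log units; within the scatter) does not separate the 3,5-difluorophenyl and 4-fluorophenyl groups, whereas a 4.1-fold higher number from compound 1 to compound 4 (0.62 log units; beyond the scatter) sets the 3,4-difluorophenyl group apart.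

Going by these compounds, the true distance between compound 3 and compound 4 remains open. So does whether chloro in place of fluoro on the aromatic carbon would retain the number of compound 1.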